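From dimethylamino to pyrrolidin-1-yl on a shared core

The source may report more compounds than this note shows. Statements on the series, on what has been measured and on what is new or still open speak of the compounds shown alone.

compound 1 `CC(=O)OC/C1=C/C[C@](C)(CCC=C(C)C)/C=C/[C@@H](OC(=O)C=C(C)C)[C@](C)(O)/C=C/C1=O`: 2950 nM
compound 2 `COC/C1=C/C[C@](C)(CCC=C(C)C)/C=C/[C@@H](OC(=O)C=C(C)C)[C@](C)(O)/C=C/C1=O`: 3070 nM
compound 3 `CC(C)=CCC[C@]1(C)/C=C/[C@@H](OC(=O)C=C(C)C)[C@](C)(O)/C=C/C(=O)/C(CN(C)C)=C\C1`: 140 nM
compound 4 `CC(C)=CCC[C@]1(C)/C=C/[C@@H](OC(=O)C=C(C)C)[C@](C)(O)/C=C/C(=O)/C(CN2CCCC2)=C\C1`: not yet measured

All three values come from a functional assay on HL-60 cells (Homo sapiens) for antiproliferative activity, read by MTT assay, with a stated time of 48 h; on this read-out higher numbers stand for weaker inhibition and lower numbers for stronger inhibition. Among them, compound 3 has the lowest number, 140 nM, and its steps to both other compounds lie beyond the scatter.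

The next change is pyrrolidin-1-yl in place of dimethylamino on a saturated chain carbon bound to a double-bonded ring carbon. In words, pyrrolidin-1-yl takes the place of dimethylamino on a saturated chain carbon bound to a double-bonded ring carbon.

Among the compounds with values here, three measured steps concern this same carbon. Exchanging one oxygen-linked group for another gave a 1.0-fold higher number from compound 1 to compound 2 (0.02 log units; within the scatter), so nothing beyond the scatter. Exchanging either oxygen-linked group for dimethylamino gave a 21-fold lower number from compound 1 to compound 3 (1.32 log units; beyond the scatter) and a 22-fold lower number from compound 2 to compound 3 (1.34 log units; beyond the scatter), both large. What sits on this carbon can therefore matter a great deal. However, no measured pair exchanges one nitrogen group for another, so the data do not directly size this step.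

Compound 4 keeps a nitrogen group on this carbon, as does compound 3 with 140 nM, so it is expected to stay near that value. The expected change in this assay is a 1.3-fold higher number from compound 3 to compound 4 (0.11 log units; within the scatter), which is no step beyond the scatter. For compound 4 the estimated value is 180 nM, with an expected range from 60 nM to 550 nM.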

Compound 4, half-maximal inhibitory concentration: 160 nM
Beside the measured number, compound 4's estimate is 1.1-fold (0.05 log units) above it; the measured number falls inside the stated range.
By their numbers in this assay, from the lowest: compounds 3 and 4 (each within the scatter of the next); then compounds 1 and 2 (each within the scatter of the next).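

In this assay, putting pyrrolidin-1-yl in place of dimethylamino gives a 1.1-fold higher number from compound 3 to compound 4 (0.06 log units; within the scatter) and so leaves the number within the scatter: on this carbon, a nitrogen group held in a ring does as well as one with two separate methyl groups. The large difference from the oxygen-linked groups also appears with this second nitrogen group, at a 19-fold lower number from compound 2 to compound 4 (1.28 log units; beyond the scatter) and at an 18-fold lower number from compound 1 to compound 4 (1.27 log units; beyond the scatter) and so it no longer rests on dimethylamino alone. No separate measurement is available to explain why these nitrogen groups stand so far from the oxygen-linked ones.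

The compounds shown cover only two nitrogen groups, so it remains open whether a larger ring such as piperidin-1-yl, a ring with a second hetero atom such as morpholin-4-yl, or a simple primary amine on this carbon would keep the number in the same range. On these data alone, whether the same pattern holds beyond this one cell line and read-out also remains open, as every value here comes from this assay alone.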